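Adding a fluoro group to compound 2

A few compounds are considered here, and "the series" means these few. Any claim that something is new, unique, unknown or untested is made for them only; others in the source may bear on it.

Compound 1 `COc1c(N2C[C@H]3CCCN(C(=O)Cn4cc(CN5C(=O)/C(=N/O)c6cccc(F)c65)nn4)[C@H]3C2)c(F)cc2c(=O)c(C(=O)O)cn(C3CC3)c12`: 16 ug/mL
Compound 2 `CO/N=C1/C(=O)N(Cc2cn(CC(=O)N3CCC[C@@H]4CN(c5c(F)cc6c(=O)c(C(=O)O)cn(C7CC7)c6c5OC)C[C@@H]43)nn2)c2ccccc21`: 128 ug/mL

In an ADME assay on Vero cells (Chlorocebus sabaeus) for cytotoxicity, read by MTT assay, with a stated time of 72 h (on this read-out higher numbers stand for lower toxicity in this test and lower numbers for higher toxicity in this test), compound 2 stands highest of the two at 128 ug/mL, beyond the scatter from compound 1. Compound 3 `CO/N=C1/C(=O)N(Cc2cn(CC(=O)N3CCC[C@@H]4CN(c5c(F)cc6c(=O)c(C(=O)O)cn(C7CC7)c6c5OC)C[C@@H]43)nn2)c2c(F)cccc21` differs from compound 2 by fluoro in place of hydrogen on an aromatic carbon. No measured pair differs in one place only, so the size of this change is not directly shown. The lower value of compound 1, 16 ug/mL, suggests a downward direction, so a modest fall around the edge of the scatter is expected. The estimated change is a 2.0-fold lower number from compound 2 to compound 3 (0.30 log units; within the scatter). For compound 3 the expected value is 64 ug/mL, with an estimated range of 24 ug/mL to 160 ug/mL.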

Compound 3, half-maximal cytotoxic concentration: 16 ug/mL
The estimate for compound 3 lay 4.0-fold (0.60 log units) above the measured number; the measured number lies below the stated range.
By their numbers in this assay, from the lowest: compounds 1 and 3 (each within the scatter of the next); then compound 2.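

Fluoro in place of hydrogen on this aromatic carbon gives an 8.0-fold lower number from compound 2 to compound 3 (0.90 log units; beyond the scatter) in this assay, so this one substitution alone moves the number beyond the scatter. Once fluoro is present, methyl in place of hydrogen on an oxygen gives no change at the digits printed from compound 1 to compound 3 (within the scatter), so that change has no visible effect in this fluoro-bearing pair. No measurement at hand gives a reason for the fall. From the compounds shown here alone, it remains open whether chloro or methoxy on the same carbon would lower the number as well. Going by these compounds, the effect of methyl in place of hydrogen on the oxygen also remains open where this carbon carries hydrogen rather than fluoro.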